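Swapping a sulfonamide arm for a methoxyphenyl group

A few compounds are considered here, and "the series" means these few. Any claim that something is new, unique, unknown or untested is made for them only; others in the source may bear on it.

Of the compounds shown here, two from a single series have been measured so far. Compound 1 `CCCCCc1ccc(-c2cn(C[C@H](O)[C@H]3OC(=O)C(OCc4ccccc4)=C3OCc3ccccc3)nn2)cc1` carries a 4-pentylphenyl group on the shared core, and in a functional assay on CFPAC-1 cells (Homo sapiens) for antiproliferative activity, read by MTT assay, with a stated time of 72 h (on this read-out lower numbers stand for stronger inhibition and higher numbers for weaker inhibition), compound 1 gives 9890 nM. Compound 2 `Cc1ccc(S(=O)(=O)NCc2cn(C[C@H](O)[C@H]3OC(=O)C(OCc4ccccc4)=C3OCc3ccccc3)nn2)cc1` instead carries a (((4-methylphenyl)sulfonyl)amino)methyl group at the same place, and in this assay compound 2 gives 68000 nM, the higher of the two numbers; the step of a 6.9-fold higher number from compound 1 to compound 2 (0.84 log units; beyond the scatter) lies beyond the scatter.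

Compound 3 `COc1ccc(-c2cn(C[C@H](O)[C@H]3OC(=O)C(OCc4ccccc4)=C3OCc3ccccc3)nn2)cc1` is the next step from compound 2. The change is 4-methoxyphenyl in place of (((4-methylphenyl)sulfonyl)amino)methyl on an aromatic carbon. Compound 3 therefore returns to a six-membered aromatic ring attached directly to the shared core, as in compound 1, with a methoxy group in place of the pentyl chain. Going by the values given here, the only step available, from compound 1 to compound 2, shows that going from a directly attached aromatic ring to the sulfonamide arm raised the number, so reversing that kind of change is expected to lower it. Compound 3 is expected to give a number near 15000 nM, within the range 5000 nM to 50000 nM, a step of a 4.5-fold lower number from compound 2 to compound 3 (0.66 log units; beyond the scatter) expected from compound 2.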

Compound 3, half-maximal inhibitory concentration: 26000 nM
Compound 3: middle estimate off by 1.7-fold (0.24 log units), on the low side; the measured number falls inside the stated range.
By their numbers in this assay, from the lowest: compound 1; then compound 3; then compound 2.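

In this assay, the step of a 2.6-fold lower number from compound 2 to compound 3 (0.42 log units; beyond the scatter) shows that the lower number seen with a directly attached aromatic ring at this aromatic carbon is not unique to the 4-pentylphenyl group, since 4-methoxyphenyl also gives a lower number than the sulfonamide arm. The step of a 2.6-fold higher number from compound 1 to compound 3 (0.42 log units; beyond the scatter) adds something that the first pair could not show: with the attached ring kept, changing only pentyl to methoxy moves the number beyond the scatter, so the attached ring alone does not fix the result and the group it carries counts as well. These three compounds therefore rank the groups at this one place, but no measurement offered here explains why the numbers shift.

From the compounds shown here alone, whether the number follows the length of the chain on the attached ring remains open, as a propyl or an octyl chain would be needed to test this, and a bare phenyl ring would show how much either group contributes. It is also unknown how an amine or a carboxylic acid on that ring would read in this assay, or whether any group here can bring the number below that of compound 1.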